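The source may hold more compounds than are shown below. What is called first, only, known or untested is meant among the compounds shown, and "the series" means these compounds.

Working notes on the series. Compound 2 `Fc1cccc(-c2nnc(Cn3nnc4ccccc43)o2)c1` is measured in an ADME assay on cells (Macrophage, Homo sapiens) for inhibition (a higher number here means that more compound is tolerated, a lower number that less compound is tolerated), only as a limit of the assay, giving > 100000 nM. Its nearest measured neighbour, compound 1 `Brc1cccc(-c2nnc(Cn3nnc4ccccc43)o2)c1`, likewise reaches only the limit and gives > 100000 nM in this assay. Going by the values given here, the one measured step, a step that the two limits leave unreadable from compound 1 to compound 2, therefore cannot be sized; all that can be said rests on (the limit of > 100000 nM in this assay, at which 2 of the 2 values shown sit), so neither value separates from the other.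

Compound 3 `COc1cccc(-c2nnc(Cn3nnc4ccccc43)o2)c1` differs from compound 2 by methoxy in place of fluoro on an aromatic carbon. Among the compounds with values here, no measured step resembles this change, and the only recorded step is itself unreadable, so nothing points to a shift in either direction. Since compound 2 already sits at the limit, the expected step that the limit leaves unreadable from compound 2 to compound 3 is none beyond the scatter. For compound 3 the estimated value in this assay is 150000 nM, within a range from 60000 nM to 400000 nM, most likely again reported only as a limit.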

Compound 3, half-maximal cytotoxic concentration: > 100000 nM
Compound 3: a limit, no number; the forecaster's own chance of this, stated with the estimate: 80%; the middle value lies beyond the limit too.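

No step among compound 1, compound 2 and compound 3 can be read in this assay, as all three stop at the assay limit: the limit of > 100000 nM in this assay, at which 3 of the 3 values shown sit.

The compounds shown leave open whether any substituent at this aromatic carbon would give a measurable value in this assay.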